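The compounds below may be only part of what the source reports. "The series", "measured", "known", "first", "only" and "open" are said of these compounds alone.

In a functional assay on cells (Cancer cell lines, Homo sapiens) for inhibition (on this read-out higher numbers stand for weaker inhibition of growth and lower numbers for stronger inhibition of growth), compound 1 `N=C(N)N/N=C/c1c(-c2ccsc2)nc2sccn12` gives 30200 nM and compound 2 `N=C(N)N/N=C/c1c(-c2cccs2)nc2sccn12` gives 29500 nM, so compound 2 stands level with compound 1 within the scatter. Compound 3 `Cc1cc(-c2nc3sccn3c2/C=N/NC(=N)N)c(C)s1` follows from compound 2 by one change: 2,5-dimethylthiophen-3-yl in place of thiophen-2-yl on an aromatic carbon. Going by the values given here, the only measured step that bears on it is a 1.0-fold lower number from compound 1 to compound 2 (0.01 log units; within the scatter), which stays within the scatter. Among the compounds with values here, no measured compound carries the 2,5-dimethylthiophen-3-yl group, so the guidance is thin. The expected change is small and not beyond the scatter, leaning slightly to a lower number: the estimate is a 1.4-fold lower number from compound 2 to compound 3 (0.15 log units; within the scatter). For compound 3 the estimated value is 21000 nM, with an expected range of 7000 nM to 60000 nM.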

Compound 3, concentration for total growth inhibition: 33100 nM
Compound 3: middle estimate off by 1.6-fold (0.20 log units), on the low side; measured number inside the range.
By their numbers in this assay, from the lowest: compounds 2, 1 and 3 (each within the scatter of the next).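

In this assay, the 2,5-dimethylthiophen-3-yl group on this aromatic carbon gives a 1.1-fold higher number from compound 2 to compound 3 (0.05 log units; within the scatter), and a 1.1-fold higher number from compound 1 to compound 3 (0.04 log units; within the scatter). The position therefore now holds a substituted thiophene as well as the two unsubstituted ones, with no step beyond the scatter. No other data on these compounds bear on this result.

On these data alone, all three compounds carry a thiophene here, so it stays open whether a phenyl ring, an amine or a carboxylic acid at this carbon would move the number beyond the scatter. Changes elsewhere on the shared core also stay open.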